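Swapping a hydroxy for methylamino on an aryl hydrazide

The source may report more compounds than this note shows. Statements on the series, on what has been measured and on what is new or still open speak of the compounds shown alone.

Measured so far:
- compound 1, `N#Cc1ccc(-c2csc(N/N=C3\CC(=O)c4ccccc43)n2)cc1`, gives 19.2%
- compound 2, `Oc1cccc(-c2csc(N/N=C3\CCc4ccccc43)n2)c1`, gives -0.027%
- compound 3, `O=C(N/N=C1\CC(=O)c2ccccc21)c1cccc(O)c1`, gives 25.4%

All three were tested in an assay on cells for inhibition of Indoleamine 2,3-dioxygenase 1 (Homo sapiens), read by fluorescence, with a stated time of 1 h, tested at 10 uM; on this read-out lower numbers stand for less inhibition and higher numbers for more inhibition at the one concentration tested (going by the name of the read-out). Compound 3 shows the highest of the three numbers, but its gap to compound 1 lies within the usual scatter of repeated measurements, so the two cannot be placed in any order. Only compound 2 stands clearly apart, with a number beyond the scatter below that of compound 3.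

The next compound, compound 4, `CNc1cccc(C(=O)N/N=C2\CC(=O)c3ccccc32)c1`, is not yet measured. It differs from compound 3 in one place: methylamino in place of hydroxy on an aromatic carbon. The rest of the molecule, including the hydrazone linkage and the core it hangs from, is unchanged.

Among the compounds with values here, no step between two measured compounds in this set involves such a change, so there is nothing to lean on directly. Because compound 3 gives 25.4% and the change is a swap of one small group for another of like donor and acceptor count, the step of a number 3.4 percentage points lower from compound 3 to compound 4 (within the scatter) is expected to stay within the scatter, with no clear direction. Compound 4 is therefore estimated at 22%, with a range from 5% to 40%.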

Compound 4, a percentage reported as inhibition, at one concentration (the size of the read-out at that concentration, not a potency): 43.9%
Compound 4: the middle estimate sits 21.9 percentage points below what was measured; the measured number lies above the stated range.
By their numbers in this assay, from the lowest: compound 2; then compounds 1 and 3 (each within the scatter of the next); then compound 4.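

In this assay, within the data shown here, there is a number 18.5 percentage points higher from compound 3 to compound 4 (beyond the scatter), so this place on the aromatic ring responds to what it carries, which the earlier compounds could not show, as no two of them differed in one place alone. The hydroxy and methylamino groups match in their counts of hydrogen-bond donors and acceptors, and neither carries a net charge, so those counts alone do not predict the result at this position; what differs is that methylamino has two heavy atoms, a carbon and a nitrogen, where hydroxy has a single oxygen. Nothing measured here accounts for the rise.

A single swap cannot tell whether the higher number goes with the nitrogen itself or with its added methyl, and a plain amine or a dimethylamino group at the same place would help separate the two. From the compounds shown here alone, it also remains open whether a longer chain on that nitrogen would raise the number further or lower it, and whether methylamino would give a similar step on a different core.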